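Swapping Dimethylamino for Isopropyl on a Sulfonyl Sulfur

The source may hold more compounds than are shown below. What is called first, only, known or untested is meant among the compounds shown, and "the series" means these compounds.

Compound 1 `C=CC(=O)Nc1cc(Nc2ncc(F)c(Nc3ccccc3S(=O)(=O)C(C)C)n2)c(OC)cc1N(C)CCN(C)C`: 15%
Compound 2 `C=CC(=O)Nc1cc(Nc2nccc(Nc3ccccc3S(=O)(=O)N(C)C)n2)c(OC)cc1N(C)CCN(C)C`: 5%

In an ADME assay on microsomes from liver (Mus musculus) for metabolic stability, read by LC-MS, using NADPH, with a stated time of 30 min, tested at 1 uM (on this read-out lower numbers stand for a less stable compound and higher numbers for a more stable compound), compound 2 gives 5%, a number within the usual scatter of compound 1 at 15%. Only these two numbers are available, and they do not isolate the effect of any single structural change. The next structure is compound 3 `C=CC(=O)Nc1cc(Nc2nccc(Nc3ccccc3S(=O)(=O)C(C)C)n2)c(OC)cc1N(C)CCN(C)C`, which has not yet been measured. Compared with compound 2, it has isopropyl in place of dimethylamino on a sulfonyl sulfur. Among the measured compounds shown here, no measured step shows what this exchange does in this assay, so no change beyond the scatter is expected, in either direction. The expected step is a number 5 percentage points higher from compound 2 to compound 3 (within the scatter). For compound 3, the estimated value is 10%, with an expected range of 2% to 25%.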

Compound 3, percent of the compound remaining: 8%
Beside the measured number, compound 3's estimate is 2 percentage points above it, within the range that was stated.
By their numbers in this assay, from the lowest: compounds 2, 3 and 1 (each within the scatter of the next).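

Read alone in this assay, isopropyl in place of dimethylamino on a sulfonyl sulfur gives a number 3 percentage points higher from compound 2 to compound 3 (within the scatter) and so leaves the read-out at this position within the scatter. Compound 3 also separates the second difference between compound 1 and compound 2: hydrogen in place of fluoro on an aromatic carbon gives a number 7 percentage points lower from compound 1 to compound 3 (within the scatter) and likewise stays within the scatter. Thus, neither single exchange shows an effect that can be told apart from the usual variation in this assay, and no supporting data bear on these results.

On these data alone, whether a longer chain or a cyclopropyl group on the sulfonyl sulfur would give a step beyond the scatter remains open. The same holds for chloro or methyl on that aromatic carbon.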